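A few compounds are considered here, and "the series" means these few. Any claim that something is new, unique, unknown or untested is made for them only; others in the source may bear on it.

In an assay for inhibition of squalene synthase (Rattus norvegicus), using microsomes (on this read-out higher numbers stand for weaker inhibition and lower numbers for stronger inhibition), compound 2 `C=CCc1ccccc1OCCCNC(C)C` gives 56 nM, the lowest of the two numbers measured. Compound 1 `CCC(=O)Nc1ccc(OCC(O)CNC(C)C)c(Cc2ccccc2)c1` gives 900 nM in this assay, a gap that lies beyond the usual scatter. Compound 3 `CC(C)NCCCOc1ccccc1Cc1ccccc1` is not yet measured and differs from compound 2 in one place: phenyl in place of vinyl on a saturated chain carbon bound to an aromatic carbon. Among the compounds with values here, no measured pair shows this change on its own, so no step from the data can guide it. The expected step from compound 2 to compound 3 is a 1.4-fold lower number from compound 2 to compound 3 (0.15 log units; within the scatter), about the size of the scatter, towards stronger inhibition. Compound 3 is estimated at 40 nM in this assay, within 15 nM to 150 nM.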

Compound 3, half-maximal inhibitory concentration: 12 nM
The estimate for compound 3 lay 3.3-fold (0.52 log units) above the measured number; measured number outside the range, below it.
By their numbers in this assay, from the lowest: compound 3; then compound 2; then compound 1.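

In this assay, phenyl in place of vinyl on a saturated chain carbon bound to an aromatic carbon gives a 4.7-fold lower number from compound 2 to compound 3 (0.67 log units; beyond the scatter), the only single change that can be read among these compounds. This position therefore accepts a six-membered aromatic ring, and the gain in inhibition exceeds ordinary measurement noise. Nothing at hand gives a reason for this gain. From the compounds shown here alone, it remains open whether a phenethyl group, with its longer chain, or a benzyl group carrying a methoxy group would strengthen inhibition further. Going by these compounds, whether the same change works on a different core also remains open.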